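The source may report more compounds than this note shows. Statements on the series, on what has been measured and on what is new or still open speak of the compounds shown alone.

In a functional assay on A549 cells (Homo sapiens) for antiproliferative activity, read by MTT assay, with a stated time of 48 h (on this read-out lower numbers stand for stronger inhibition and higher numbers for weaker inhibition), compound 1 (`COc1ccc(C(=O)c2ccc(OC)c3c2OC(C)(C)C=C3)c(NC(=O)CBr)c1`) gives 1210 nM and compound 2 (`COc1ccc(C(=O)c2ccc3c(c2)C=CC(C)(C)O3)c(NC(=O)CBr)c1`) gives 1980 nM as its number. These two values lie within the scatter of each other, so compound 2 stands with compound 1 and not apart from it. Compound 3 (`COc1ccc(C(=O)c2ccc3c(c2)C=CC(C)(C)O3)c(NC(=O)CO)c1`) departs from compound 2 in one place. The change hydroxy in place of bromo on a saturated chain carbon bound to a carbonyl carbon amounts to hydroxy in place of bromo on a saturated chain carbon bound to a carbonyl carbon. Among the compounds with values here, no measured pair shows this change, and both measured compounds carry the bromo, so the expectation rests on thin ground. A move towards a higher number in this assay is expected, of a size beyond the scatter. The expected step is a 3.0-fold higher number from compound 2 to compound 3 (0.48 log units; beyond the scatter) in this read-out. For compound 3 the estimate is 6000 nM with an expected range of 1800 nM to 20000 nM in this read-out.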

Compound 3, half-maximal inhibitory concentration: 90 nM
Estimate against measurement, compound 3: 67-fold (1.82 log units) above, and the stated range ends above it.
By their numbers in this assay, from the lowest: compound 3; then compounds 1 and 2 (each within the scatter of the next).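

On the saturated chain carbon bound to a carbonyl carbon, the group carried there has a large effect in this assay: hydroxy in place of bromo gives a 22-fold lower number from compound 2 to compound 3 (1.34 log units; beyond the scatter) and sets compound 3 apart from the pair that shares the bromo. Compound 1 and compound 2 both carry the bromo and could say nothing about this position, whereas compound 3 shows that the bromo is not required for activity on this core. Nothing measured here accounts for the size of the step.

On these data alone, only bromo and hydroxy stand at this place, so it remains open whether the gain belongs to hydroxy itself or to the loss of bromo. As far as these compounds go, an amine, a methoxy group or a longer chain ending in hydroxy would help separate these readings, and the effect of the same change on the core of compound 1 also remains open.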